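The source may hold more compounds than are shown below. What is called first, only, known or untested is meant among the compounds shown, and "the series" means these compounds.

Compound 1, `C#CCCCCCCCCCOC(=O)c1ccn(-c2cccc(OC(=O)NCCCCCCc3ccccc3)c2)c1`: > 200 nM
Compound 2, `Cc1cc(C(N)=O)c(-c2cccc(OC(=O)NC3CCCCC3)c2)o1`: > 70 nM
Compound 3, `COc1cccc(-c2c(C(=O)NCCCCCc3ccccc3)cc(C)n2Cc2ccccc2)c1`: > 50000 nM

All three values come from an assay (brain) for inhibition of Fatty-acid amide hydrolase 1 (Mus musculus), with stated times of 20 min and 15 min; a higher number here means a weaker inhibitor, a lower number a stronger inhibitor. In this assay compound 1 gives > 200 nM, which is a limit of the assay rather than a number. Compound 2 gives > 70 nM, also a limit. Compound 3 gives > 50000 nM, once more a limit, as recorded in the limit of > 50000 nM in this assay, at which 1 of the 3 values shown sits. Since none of the three has a measured number, no ordering among them can be drawn, and compound 3 stands only as a compound for which the assay reports no inhibition up to its limit.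

Compound 4, `COc1cccc(-c2c(C(=O)NCCCCCCc3ccccc3)cc(C)n2Cc2ccccc2)c1`, is the next compound to be examined. It differs from compound 3 in one place: benzyl in place of phenyl on a saturated chain carbon, five bonds along the chain from an amide-type nitrogen. Going by the values given here, no measured pair shows the effect of this change, so its size is unknown. Compound 4 is expected to give a value close to that of compound 3, with the step from compound 3 to compound 4 estimated as a number no higher from compound 3 to compound 4 (the limit leaves the size open), not beyond the scatter. The estimate for compound 4 is therefore 50000 nM, ranging from 10000 nM to 200000 nM, most likely reported again only as a limit.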

Compound 4, half-maximal inhibitory concentration: > 200 nM
Compound 4 was reported as a limit; the forecaster's own chance of this, stated with the estimate: 75%; the middle value lies beyond the limit too.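

Compound 3 and compound 4 are each recorded only as a limit, so the step between them cannot be read. The compounds shown leave open whether benzyl in place of phenyl on this chain changes inhibition at all in this assay and how strongly any of the four compounds inhibits.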